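The compounds below may be only part of what the source reports. "The series", "measured", "known", "first", "only" and "open" are said of these compounds alone.

Compound 1 `COc1ccc(/C=C/C2CC=CC(=O)O2)cc1` and compound 2 `COc1ccc(/C=C/C2CC=CC(=O)O2)c(OC)c1` share one core and differ by methoxy in place of hydrogen on an aromatic carbon. In a functional assay on 786-0 cells (Homo sapiens) for inhibition, read by sulforhodamine B assay, with a stated time of 48 h (a lower number here means a stronger inhibitor of growth, a higher number a weaker inhibitor of growth), compound 1 gives 21.6 uM, and compound 2 gives 4.1 uM, a step of a 5.3-fold lower number from compound 1 to compound 2 (0.72 log units; beyond the scatter). Compound 3 `COc1ccc(/C=C/C2CC=CC(=O)N2)cc1OC` has a different core, and the difference between the two cores is not broken down here. For compound 3 this assay reports only a limit, > 964 uM, which is the limit of > 964 uM in this assay, at which 1 of the 3 values shown sits. Compound 4 `COc1cc(OC)c(OC)cc1/C=C/C1CC=CC(=O)N1` differs from compound 3 by methoxy in place of hydrogen on an aromatic carbon; this is the same kind of change as before, though here the entering group is also para to a methoxy group. Because compound 3 sits at the limit of > 964 uM in this assay, at which 1 of the 3 values shown sits, even a step like the earlier one would leave compound 4 weak, so the expected step is an at least 1.9-fold lower number from compound 3 to compound 4 (0.28 log units; that floor lies within the scatter). Compound 4 is estimated at 500 uM, likely between 150 uM and 2000 uM, with a real chance of another limit.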

Compound 4, concentration for growth inhibition (reported as GI): > 864 uM
Compound 4: no number, only a limit (the forecaster's own chance of this, stated with the estimate: 55%); at least 1.7-fold (0.23 log units) between middle value and limit.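

The step from compound 3 to compound 4 cannot be read: each compound has only a limit, not a number. The compounds shown leave open whether methoxy in place of hydrogen changes growth inhibition on their shared core.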